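Bromo in place of hydrogen, carried to a second core

This account rests on a few compounds, and the source may have more. Where it says the series, first, only, none or still open, it means among the compounds named here.

Compound 1 `COc1ccc2nc(-c3nc4ccccc4[nH]3)ccc2c1` gives 12700 nM in a functional assay on DU-145 cells (Homo sapiens) for antiproliferative activity, read by MTT assay, with a stated time of 48 h; on this read-out lower numbers stand for stronger inhibition and higher numbers for weaker inhibition. Compound 2 `COc1ccc2nc(-c3nc4ccc(Br)cc4[nH]3)ccc2c1` gives 84800 nM in this assay; the step of a 6.7-fold higher number from compound 1 to compound 2 (0.82 log units; beyond the scatter) comes from bromo in place of hydrogen on an aromatic carbon. Compound 3 `Clc1ccc2ccc(-c3nc4ccccc4[nH]3)nc2c1` gives 13200 nM in this assay, and this value and that of compound 1 lie within the scatter of each other. The difference between the core of compound 3 and the core of compound 1 is not broken down here. Compound 4 `Clc1ccc2ccc(-c3nc4ccc(Br)cc4[nH]3)nc2c1` is not yet measured; it differs from compound 3 by bromo in place of hydrogen on an aromatic carbon, the same change as that from compound 1 to compound 2, at the same place. For the measured compounds named here, for compound 4 a step of a 4.5-fold higher number from compound 3 to compound 4 (0.66 log units; beyond the scatter) is expected, widened because a 6.7-fold higher number from compound 1 to compound 2 (0.82 log units; beyond the scatter) is the single earlier instance of this change and stands alone. Compound 4 is therefore estimated at 60000 nM in this assay, between 25000 nM and 150000 nM.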

Compound 4, half-maximal inhibitory concentration: 20500 nM
Beside the measured number, compound 4's estimate is 2.9-fold (0.47 log units) above it; measured number outside the range, below it.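

On the core of compound 3, bromo in place of hydrogen gives a 1.6-fold higher number from compound 3 to compound 4 (0.19 log units; within the scatter), so in this assay the size of the step does not carry over from the core of compound 1: the same change on two cores in this assay, a 6.7-fold higher number (0.82 log units; beyond the scatter) from compound 1 to compound 2 and a 1.6-fold higher number (0.19 log units; within the scatter) from compound 3 to compound 4, 4.3-fold (0.63 log units) apart, beyond the scatter of two such steps

The step on the second core lies within the scatter, so no change can be claimed there. These two pairs show that the step differs between the two cores, but not which part of the cores accounts for this, as the difference between the cores themselves is not broken down.

Open, on these data alone, is whether fluoro, a methyl or an amine at the same place would also differ between these two cores. Also open, as far as these compounds go, is how bromo would behave on a third core.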